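The source may report more compounds than this note shows. Statements on the series, on what has been measured and on what is new or still open speak of the compounds shown alone.

Of the compounds shown here, three sharing one core have been tested in a functional assay on L1210 cells (Mus musculus) for cytotoxicity, read by cell counting, with a stated time of 2 days; on this read-out lower numbers stand for stronger inhibition and higher numbers for weaker inhibition. Compound 1 `C=C(Br)C(=O)Nc1ccc(/C=C2\SC(=O)N(CC)C2=O)cc1` gives 500 nM in this assay. Compound 2 `C=C(Br)C(=O)Nc1ccc(/C=C2\SC(=O)N(Cc3ccc(C)cc3)C2=O)cc1` gives 3400 nM, and compound 3 `C=C(Br)C(=O)Nc1ccc(/C=C2\SC(=O)N(Cc3ccc(C(F)(F)F)cc3)C2=O)cc1` gives 12000 nM. Compound 3 therefore stands highest of the three numbers: its nearest neighbour is compound 2, separated by a 3.5-fold higher number from compound 2 to compound 3 (0.55 log units; beyond the scatter), and its furthest is compound 1, separated by a 24-fold higher number from compound 1 to compound 3 (1.38 log units; beyond the scatter).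

The next compound, compound 4 `C=C(Br)C(=O)Nc1ccc(/C=C2\SC(=O)N(C)C2=O)cc1`, differs from compound 3 in one place: hydrogen in place of 4-(trifluoromethyl)phenyl on a saturated chain carbon bound to an amide-type nitrogen in a ring. Among the measured compounds shown here, two measured steps bear on this change, since both replace methyl on that saturated chain carbon with a substituted phenyl and both raise the number: a 6.8-fold higher number from compound 1 to compound 2 (0.83 log units; beyond the scatter) and a 24-fold higher number from compound 1 to compound 3 (1.38 log units; beyond the scatter). Compound 4 undoes the larger of these, returning a substituted phenyl to a single hydrogen at the same place, so a large step downward in this assay is expected, of roughly the size seen in the step from compound 1 to compound 3 but in the opposite direction.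

Compound 4 is thus expected to give about 500 nM, within a range of 200 nM to 1500 nM, because of the step of a 24-fold higher number from compound 1 to compound 3 (1.38 log units; beyond the scatter). That estimate corresponds to an expected step of a 24-fold lower number from compound 3 to compound 4 (1.38 log units; beyond the scatter), well beyond the scatter.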

Compound 4, half-maximal inhibitory concentration: 190 nM
Compound 4: the middle estimate sits 2.6-fold (0.42 log units) above what was measured; the whole stated range lies above it.
By their numbers in this assay, from the lowest: compound 4; then compound 1; then compound 2; then compound 3.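

In this assay this position no longer shows only that adding a substituted phenyl raises the number: hydrogen in place of 4-(trifluoromethyl)phenyl gives a large drop (a 63-fold lower number from compound 3 to compound 4 (1.80 log units; beyond the scatter)), and hydrogen in place of 4-methylphenyl gives another (an 18-fold lower number from compound 2 to compound 4 (1.25 log units; beyond the scatter)). Even the smallest change, hydrogen in place of methyl on the same saturated chain carbon, lies beyond the scatter (a 2.6-fold lower number from compound 1 to compound 4 (0.42 log units; beyond the scatter)), so the methyl of compound 1 did not mark the lowest number reachable at this place, and compound 4 now stands as the most potent of the four. Across the four compounds the numbers rise in a single order, from hydrogen through methyl and 4-methylphenyl to 4-(trifluoromethyl)phenyl, and none of them goes against that order.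

Nothing measured here accounts for this order. The compounds shown leave open where a longer chain, an unsubstituted phenyl, an amine or a carboxylic acid on this carbon would fall in that order, and whether any group there could bring the number lower than that of compound 4.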